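Methyl to chloro on the 4-substituted phenyl ring

The source may report more compounds than this note shows. Statements on the series, on what has been measured and on what is new or still open speak of the compounds shown alone.

Measured so far, with this read-out:
compound 1 `O=C1CSC(N2N=C(c3ccc(Cl)cc3)CC2c2cccc3ccccc23)=N1`: 16500 nM
compound 2 `Cc1ccc(C2=NN(C3=NC(c4ccccc4)CS3)C(c3cccc4ccccc34)C2)cc1C`: 7250 nM
compound 3 `Cc1ccc(C2=NN(C3=NC(c4ccccc4)CS3)C(c3cccc4ccccc34)C2)cc1`: 10400 nM

In a functional assay on HepG2 cells (Homo sapiens) for inhibition, read by CCK-8 assay, with a stated time of 48 h (on this read-out lower numbers stand for stronger inhibition and higher numbers for weaker inhibition), compound 3 stands second highest of the three numbers. Its nearest neighbour is compound 2, and the step of a 1.4-fold higher number from compound 2 to compound 3 (0.16 log units; within the scatter) lies within the scatter. Compound 1 differs from compound 3 in more than one place, so only the two values can be set side by side; they too lie within the scatter of each other.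

Compound 4 `Clc1ccc(C2=NN(C3=NC(c4ccccc4)CS3)C(c3cccc4ccccc34)C2)cc1` is not yet measured. It differs from compound 3 by chloro in place of methyl on an aromatic carbon. Going by the values given here, no measured step reports this exact exchange; the only single-point step, from compound 2 to compound 3 on the same ring, was small. Hence the expected step of a 1.0-fold lower number from compound 3 to compound 4 (0.02 log units; within the scatter) is none beyond the scatter. Compound 4 is estimated at 10000 nM, with a range from 4000 nM to 25000 nM.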

Compound 4, half-maximal inhibitory concentration: 18700 nM
Estimate against measurement, compound 4: 1.9-fold (0.27 log units) below; low and high end bracket the measured number.
By their numbers in this assay, from the lowest: compounds 2, 3, 1 and 4 (each within the scatter of the next, the first and the last beyond it).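

In this assay the change from 4-methylphenyl to 4-chlorophenyl gives a 1.8-fold higher number from compound 3 to compound 4 (0.25 log units; within the scatter) and so leaves chloro and methyl unseparated at this place. Against 3,4-dimethylphenyl, 4-chlorophenyl gives the first step on this ring beyond the scatter, a 2.6-fold higher number from compound 2 to compound 4 (0.41 log units; beyond the scatter) and modest in size. With 4-chlorophenyl held, exchanging the group on the amine nitrogen in a ring gives a 1.1-fold higher number from compound 1 to compound 4 (0.05 log units; within the scatter) and separates the two groups no further. On these data alone, whether an amine or a carboxylic acid at this place would move the number stays open. Nothing on hand gives a reason for any of these steps.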